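The source may report more compounds than this note shows. Statements on the series, on what has been measured and on what is new or still open speak of the compounds shown alone.

Compound 1 `COC(=O)N(C)C(C)C#CCN1CCCC1` and compound 2 `COC(=O)N(C)C(C)C#CCn1ccnc1` share one core; compound 3 `CN(C)C(=O)N(C)CC#CCN1CCCC1` and compound 4 `CN(C)C(=O)N(C)CC#CCn1ccnc1` share another. The difference between the two cores is not broken down here. In a functional assay on the whole organism for antagonist activity, with Mus musculus as the target (on this read-out lower numbers stand for an effect already at smaller amounts and higher numbers for an effect only at larger amounts of compound), compound 1 gives > 100 mg/kg, a limit of the assay and not a number. In this assay compound 2 gives > 100 mg/kg, likewise a limit. The change from compound 1 to compound 2 is 1H-imidazol-1-yl in place of pyrrolidin-1-yl on a saturated chain carbon bound to a triple-bonded carbon; the step that the two limits leave unreadable from compound 1 to compound 2. In this assay compound 3 gives > 10 mg/kg, also a limit. Across the set there is the limit of > 10 mg/kg in this assay, at which 1 of the 3 values shown sits, and (the limit of > 100 mg/kg in this assay, at which 2 of the 3 values shown sit), so no value here is a number. From compound 3 to compound 4 the same change is made at the same place: 1H-imidazol-1-yl in place of pyrrolidin-1-yl on a saturated chain carbon bound to a triple-bonded carbon. The earlier step is not readable, so the step expected from compound 3 to compound 4 is set at a step that the limit leaves unreadable from compound 3 to compound 4. This expectation rests on compound 3 giving only > 10 mg/kg. Compound 4 is expected to give about 50 mg/kg in this assay, within 15 mg/kg to 300 mg/kg, most probably again reported as a limit.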

Compound 4, dose for half-maximal effect: > 100 mg/kg
Compound 4: a limit, no number; the forecaster's own chance of this, stated with the estimate: 75%; at least 2.0-fold (0.30 log units) between middle value and limit.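

In this assay compound 1, compound 2, compound 3 and compound 4 all stand as limits, not numbers, so neither step with the pyrrolidin-1-yl to 1H-imidazol-1-yl change can be read. The compounds shown leave open whether this change shifts the half-maximal dose on either core, and by how much.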